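Methoxy for chloro: clearance notes toward compound 3

This account rests on a few compounds, and the source may have more. Where it says the series, first, only, none or still open, it means among the compounds named here.

Measured so far:
compound 1, `Brc1cccc2c1nnn2Cc1ccccc1`: 2.3 mL/min/g
compound 2, `Clc1cccc2c1nnn2CC1CC1`: 5.7 mL/min/g

Both compounds were run in an ADME assay on microsomes from liver (Mus musculus, strain NMRI) for metabolic stability, tested at 2.5 uM; a lower number here means slower removal, a higher number faster removal of the compound. Of the two numbers, compound 2 stands highest; its nearest neighbour is compound 1, whose number is lower by a gap that lies beyond the usual scatter. Within the data shown here, the two compounds differ in more than one place, so no single step between them is computed, and their two values are all that can be said of the pair.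

The next compound, compound 3, `COc1cccc2c1nnn2CC1CC1`, is not yet measured. It differs from compound 2 in one place: methoxy in place of chloro on an aromatic carbon.

Among the measured compounds shown here, no measured step exists for this kind of change. The starting point is known only because compound 2 gives 5.7 mL/min/g in this assay. On that basis the expected step in this assay is a modest one upward, a 1.3-fold higher number from compound 2 to compound 3 (0.12 log units; within the scatter), of a size that may sit at the edge of the scatter. Compound 3 is therefore estimated at about 7.5 mL/min/g, with a range from 3.5 mL/min/g to 16 mL/min/g.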

Compound 3, intrinsic clearance in a liver preparation (reported as CLH), per the amount of preparation that the assay uses: 8.3 mL/min/g
Compound 3: middle estimate off by 1.1-fold (0.04 log units), on the low side; the range from low to high includes it.
By their numbers in this assay, from the lowest: compound 1; then compounds 2 and 3 (each within the scatter of the next).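

In this assay, among these compounds, the first step that changes one place only reads a 1.5-fold higher number from compound 2 to compound 3 (0.16 log units; within the scatter) and so gives the series its first direct reading at this aromatic carbon, ortho to a fused ring and meta to a fused ring. Methoxy in place of chloro, with 2 heavy atoms and 1 hydrogen-bond acceptor entering where 1 heavy atom and 0 hydrogen-bond acceptors leave, therefore gives compound 2 and compound 3 numbers that cannot be told apart in this read-out, and this single pair shows that the position tolerates this exchange without a clear separation in clearance. No other measurement accompanies the pair, so the data offer no account of what lies behind the two numbers.

On these data alone, it remains open how a quite different group at this carbon, such as an amine or a carboxylic acid, would read in this assay on the shared core. Also open, as far as these compounds go, is whether methoxy in place of chloro would read the same with a group other than the cyclopropylmethyl chain of compound 2 and compound 3 on the core.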